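The source may report more compounds than this note shows. Statements on the series, on what has been measured and on what is new or still open speak of the compounds shown alone.

Working notes on the series. All three measured members share one core, differing only in the aryl group on the hydrazone side. Compound 1 `COc1cc(/C=N/NC(=O)COc2cccc3ccccc23)cc(OC)c1OC` returns only a limit in an ADME assay on HEL cells (Homo sapiens) for cytotoxicity (a lower number here means that less compound is tolerated, a higher number that more compound is tolerated), namely >= 20 ug/mL. Compound 3 `O=C(COc1cccc2ccccc12)N/N=C/c1cccc([N+](=O)[O-])c1` also returns a limit in this assay, >= 20 ug/mL. Going by the values given here, compound 2 `O=C(COc1cccc2ccccc12)N/N=C/c1ccc(O)cc1` is the one member with an actual number in this assay, 20 ug/mL, and that number coincides with the limit of >= 20 ug/mL in this assay, at which 2 of the 3 values shown sit. Compound 4 `O=C(COc1cccc2ccccc12)N/N=C/c1ccc(Cl)cc1` is the next member, differing from compound 2 by chloro in place of hydroxy on an aromatic carbon. Among the compounds with values here, no measured step covers this change, so in this assay the expected step is no change at the digits printed from compound 2 to compound 4 (within the scatter), if anything toward less compound tolerated, but not beyond the scatter. Compound 4 is therefore estimated at 20 ug/mL, within 10 ug/mL to 40 ug/mL.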

Compound 4, minimum cytotoxic concentration: 100 ug/mL
Compound 4: the middle estimate sits 5.0-fold (0.70 log units) below what was measured; measured number outside the range, above it.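

In this assay, going by these compounds alone, the change from 4-hydroxyphenyl to 4-chlorophenyl gives a 5.0-fold higher number from compound 2 to compound 4 (0.70 log units; beyond the scatter), the first step that can be read as a number. This shows that a single replacement on the aromatic ring, para to a large group, can move this read-out beyond the scatter. Compound 1 and compound 3 cannot be ranked against compound 4, since each of them gives only a limit: the limit of >= 20 ug/mL in this assay, at which 2 of the 4 values shown sit.

The compounds shown do not separate the effect of adding chloro from that of losing hydroxy. Going by these compounds, how an amine or a carboxylic acid at this place would read remains open.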